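Replacing Isobutyl by a Substituted Phenyl in Cytotoxicity

The compounds below may be only part of what the source reports. "The series", "measured", "known", "first", "only" and "open" are said of these compounds alone.

Three compounds share one core and differ only in the group on one aromatic carbon. In an ADME assay on HepG2 cells (Homo sapiens) for cytotoxicity, read by luminescence, CellTiter-Glo and ATP content, with a stated time of 72 h (a higher number here means that more compound is needed for the effect, a lower number that less compound is needed), compound 1 `COc1cccc(CNCCCNc2ccnc3cc(CCC(C)C)ccc23)c1O` gives 5390 nM, compound 2 `COc1cccc(CNCCCNc2ccnc3cc(-c4ccccc4)ccc23)c1O` gives 3210 nM, and compound 3 `COc1cccc(CNCCCNc2ccnc3cc(CC(C)C)ccc23)c1O` gives 2920 nM. Compound 3 sits at the low end of these numbers, yet the gaps a 1.8-fold lower number from compound 1 to compound 3 (0.27 log units; within the scatter) and a 1.1-fold lower number from compound 2 to compound 3 (0.04 log units; within the scatter) both fall within the scatter. Compound 4 `COc1cccc(CNCCCNc2ccnc3cc(-c4ccc(C(C)(C)C)cc4)ccc23)c1O` carries 4-(tert-butyl)phenyl in place of isobutyl on an aromatic carbon. Going by the values given here, the steps that bear on this change, a 1.7-fold lower number from compound 1 to compound 2 (0.23 log units; within the scatter) and a 1.1-fold lower number from compound 2 to compound 3 (0.04 log units; within the scatter), show that swapping an open chain for a phenyl at this position moved nothing beyond the scatter. The expectation for a 1.0-fold higher number from compound 3 to compound 4 (0.01 log units; within the scatter) in this assay is therefore no step beyond the scatter. Compound 4 is estimated at 3000 nM, within 1200 nM to 8000 nM.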

Compound 4, half-maximal effective concentration: 690 nM
For compound 4 the middle estimate is 4.3-fold (0.64 log units) above the measured one; the whole stated range lies above it.
By their numbers in this assay, from the lowest: compound 4; then compounds 3, 2 and 1 (each within the scatter of the next).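

Steps beyond the scatter appear at this aromatic carbon only with 4-(tert-butyl)phenyl: in this assay adding tert-butyl to the phenyl gives a 4.7-fold lower number from compound 2 to compound 4 (0.67 log units; beyond the scatter) and the whole group gives a 4.2-fold lower number from compound 3 to compound 4 (0.63 log units; beyond the scatter) in place of isobutyl and a 7.8-fold lower number from compound 1 to compound 4 (0.89 log units; beyond the scatter) in place of isopentyl. The open chains and the unsubstituted phenyl stay within the scatter of one another, so here it is the added tert-butyl that goes with less compound being needed for the effect. Nothing shown here gives a cause for this step. On these data alone, whether an amine, a carboxylic acid or a methyl in place of the tert-butyl would give a step of this size stays open.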